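The compounds below may be only part of what the source reports. "The series", "measured", "known", "first", "only" and "open" are said of these compounds alone.

Compounds measured so far:
compound 1 `O=C(NO)c1ccc(NCc2nc(-c3ccccc3)nn2-c2ccccc2Cl)cc1`, 9630 nM
compound 2 `O=C(NO)c1ccc(NCc2nc(-c3ccccc3)nn2-c2cccc(Cl)c2)cc1`, 13700 nM
compound 3 `Cc1cccc(-n2nc(-c3ccccc3)nc2CNc2ccc(C(=O)NO)cc2)c1`, 13200 nM

These three share one core and differ only in the aryl group on an aromatic nitrogen. In a functional assay on MGC-803 cells (Homo sapiens) for antiproliferative activity, read by MTT assay, with a stated time of 72 h (on this read-out higher numbers stand for weaker inhibition and lower numbers for stronger inhibition), compound 3 lies among the others: a 1.0-fold lower number from compound 2 to compound 3 (0.02 log units; within the scatter) and a 1.4-fold higher number from compound 1 to compound 3 (0.14 log units; within the scatter), so nothing separates the three.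

Compound 4 `Cc1ccccc1-n1nc(-c2ccccc2)nc1CNc1ccc(C(=O)NO)cc1` is the next step from compound 3: 2-methylphenyl in place of 3-methylphenyl on an aromatic nitrogen. Every change among the measured compounds bears on it, since each moves or swaps the same aryl substituent: a 1.4-fold higher number from compound 1 to compound 2 (0.15 log units; within the scatter), a 1.4-fold higher number from compound 1 to compound 3 (0.14 log units; within the scatter) and a 1.0-fold lower number from compound 2 to compound 3 (0.02 log units; within the scatter). None of these left the scatter, so in this assay no step beyond the scatter is expected from compound 3 to compound 4: a 1.1-fold lower number from compound 3 to compound 4 (0.06 log units; within the scatter).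

Compound 4 is therefore estimated at 11500 nM, with a range from 5500 nM to 25000 nM.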

Compound 4, half-maximal inhibitory concentration: 12300 nM
For compound 4 the middle estimate is 1.1-fold (0.03 log units) below the measured one; measured number inside the range.
By their numbers in this assay, from the lowest: compounds 1, 4, 3 and 2 (each within the scatter of the next).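

Moving the methyl from 3-methylphenyl to 2-methylphenyl gives no change that can be told from noise in this assay, a 1.1-fold lower number from compound 3 to compound 4 (0.03 log units; within the scatter), so shifting the methyl matters no more than shifting the chloro did. Compound 4 is equally close to both chloro compounds, with a 1.1-fold lower number from compound 2 to compound 4 (0.05 log units; within the scatter) and a 1.3-fold higher number from compound 1 to compound 4 (0.11 log units; within the scatter). Methyl in place of chloro reads alike whether it turns 3-chlorophenyl into 3-methylphenyl or 2-chlorophenyl into 2-methylphenyl: the same change on two cores in this assay, a 1.0-fold lower number (0.02 log units; within the scatter) from compound 2 to compound 3 and a 1.3-fold higher number (0.11 log units; within the scatter) from compound 1 to compound 4, 1.3-fold (0.12 log units) apart, within the scatter of two such steps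

The compounds shown leave open whether an amine or a carboxylic acid on this aryl ring would give a step beyond the scatter.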